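From sec-butyl to isobutyl in a short series

A few compounds are considered here, and "the series" means these few. Any claim that something is new, unique, unknown or untested is made for them only; others in the source may bear on it.

Within the data shown here, in an ADME assay on microsomes from liver (Mus musculus) for metabolic stability, read by LC-MS, using NADPH, tested at 1 uM (a lower number here means that the compound disappears faster, a higher number that the compound lasts longer), compound 1 `CCOC(=O)NS(=O)(=O)c1sc(CC(C)C)cc1-c1cccc(Cn2ccnc2)c1` gives 3 h and compound 2 `CCC(C)OC(=O)NS(=O)(=O)c1sc(CC(C)C)cc1-c1cccc(Cn2ccnc2)c1` gives 0.783 h, the lower of the two numbers so far. Compound 3 `CC(C)COC(=O)NS(=O)(=O)c1sc(CC(C)C)cc1-c1cccc(Cn2ccnc2)c1` has not yet been measured. It differs from compound 2 by isobutyl in place of sec-butyl on an oxygen next to a carbonyl group, with the same atoms joined differently. Among the measured compounds shown here, only one measured step bears on this change: a 3.8-fold lower number from compound 1 to compound 2 (0.58 log units; beyond the scatter), with ethyl in place of hydrogen on a saturated chain carbon. That step is modest, though beyond the scatter, and it adds atoms, whereas the new change adds none. It is therefore only a loose guide. A small rise towards the number of compound 1 is expected, and it may not exceed the scatter. The expected change is a 1.5-fold higher number from compound 2 to compound 3 (0.19 log units; within the scatter). Compound 3 is estimated at 1.2 h, with an expected range from 0.55 h to 2.8 h.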

Compound 3, half-life: 0.633 h
Estimate against measurement, compound 3: 1.9-fold (0.28 log units) above; low and high end bracket the measured number.
By their numbers in this assay, from the lowest: compounds 3 and 2 (each within the scatter of the next); then compound 1.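

In this assay, rearranging sec-butyl into isobutyl on the oxygen next to a carbonyl group, with the same atoms joined differently, gives a 1.2-fold lower number from compound 2 to compound 3 (0.09 log units; within the scatter) and so does not separate the two branched groups. The second branched group also stands apart from compound 1, with a 4.7-fold lower number from compound 1 to compound 3 (0.68 log units; beyond the scatter) beside the earlier 3.8-fold lower number from compound 1 to compound 2 (0.58 log units; beyond the scatter), so the gap to compound 1 is not particular to sec-butyl. No evidence is available here that would account for this result.

From the compounds shown here alone, whether a straight butyl chain, a tert-butyl group or a cyclopropylmethyl group on the same oxygen would sit with compound 2 and compound 3 or with compound 1 remains open. Going by these compounds, it is also open whether an amine or a carboxylic acid carried on such a chain would alter this picture.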